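The source may hold more compounds than are shown below. What is called first, only, known or untested is meant among the compounds shown, and "the series" means these compounds.

Measured so far:
compound 1 `CC/N=C(/NC#N)NCCCCCn1nc(-c2ccccc2)ccc1=O` — 100 mg/kg
compound 2 `N/C(S)=N/CCCCn1nc(-c2ccccc2)ccc1=O` — 36.3 mg/kg

In a functional assay on the whole organism (stomach) with Rattus norvegicus as the target (on this read-out higher numbers stand for an effect only at larger amounts of compound and lower numbers for an effect already at smaller amounts), compound 2 stands lowest of the two numbers; its nearest neighbour is compound 1, whose value lies beyond the scatter. Compound 3 `C/N=C(/NC#N)NCCCCCn1nc(-c2ccccc2)ccc1=O` is not yet measured. It differs from compound 2 as follows: a group of 8 heavy atoms (4 carbon, 4 nitrogen; no ring) in place of a group of 4 heavy atoms (1 carbon, 2 nitrogen, 1 sulfur; no ring), on a saturated chain carbon, four bonds along the chain from an aromatic nitrogen. Going by the values given here, no step between measured compounds is available for this change. The expected direction is an increase, of a size beyond the scatter, since compound 1 in this assay gives 100 mg/kg. Compound 3 is estimated at 80 mg/kg, with a range of 30 mg/kg to 200 mg/kg, an expected step of a 2.2-fold higher number from compound 2 to compound 3 (0.34 log units; beyond the scatter).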

Compound 3, dose for half-maximal effect: 100 mg/kg
Beside the measured number, compound 3's estimate is 1.3-fold (0.10 log units) below it; low and high end bracket the measured number.
By their numbers in this assay, from the lowest: compound 2; then compounds 1 and 3 (each within the scatter of the next).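

In this assay, going by these compounds alone, the group of 8 heavy atoms in place of the group of 4 heavy atoms gives a 2.8-fold higher number from compound 2 to compound 3 (0.44 log units; beyond the scatter) at this chain position, the first reading of this change. Within the larger group, hydrogen in place of methyl on a saturated chain carbon bound to a double-bonded nitrogen gives no change at the digits printed from compound 1 to compound 3 (within the scatter) and so leaves the read-out unmoved. Nothing measured here explains either step. Still open, as far as these compounds go, is how an amine or a carboxylic acid would read at this position, and whether a longer chain would shift the number.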